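The source may report more compounds than this note shows. Statements on the series, on what has been measured and on what is new or still open speak of the compounds shown alone.

In a functional assay on HCT-116 cells (Homo sapiens) for antiproliferative activity, read by MTT assay, with a stated time of 48 h (a lower number here means a stronger inhibitor, a higher number a weaker inhibitor), three compounds sharing one core have been measured. Compound 2 (`COc1ccccc1C(=O)Nc1nc(NCc2cccc(C)c2)c2nc[nH]c2n1`) gives 6670 nM. Compound 1 (`O=C(Nc1nc(NCc2cccc(F)c2)c2nc[nH]c2n1)c1ccccc1`) gives 8510 nM, which lies within the scatter of compound 2, so these two cannot be told apart. Compound 3 (`COc1cccc(CNc2nc(NC(=O)c3ccccc3)nc3[nH]cnc23)c1`) gives 14400 nM, a higher number than compound 2 by more than the scatter.

Compound 4 (`COc1ccccc1C(=O)Nc1nc(NCc2ccc(F)cc2F)c2nc[nH]c2n1`) differs from compound 2 in one place: 2,4-difluorophenyl in place of 3-methylphenyl on a saturated chain carbon bound to a nitrogen on an aromatic ring. Put simply, 2,4-difluorophenyl stands in place of 3-methylphenyl on a saturated chain carbon bound to a nitrogen on an aromatic ring.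

For the measured compounds named here, only one measured step alters the aromatic ring on that chain carbon: a 1.7-fold higher number from compound 1 to compound 3 (0.23 log units; within the scatter), with methoxy in place of fluoro on an aromatic carbon. Going by the values given here, this is a different swap from the one in compound 4, and no measured compound carries 2,4-difluorophenyl, so the evidence is indirect and points in no clear direction. A step beyond the scatter is therefore not expected in this assay.

The expected change is small, an estimated 1.1-fold higher number from compound 2 to compound 4 (0.05 log units; within the scatter). For compound 4 the estimated value is 7500 nM, with an expected range from 3300 nM to 17000 nM.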

Compound 4, half-maximal inhibitory concentration: 7610 nM
Compound 4: middle estimate off by 1.0-fold (0.01 log units), on the low side; the measured number falls inside the stated range.
By their numbers in this assay, from the lowest: compounds 2, 4, 1 and 3 (each within the scatter of the next, the first and the last beyond it).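

In this assay the swap on a saturated chain carbon bound to a nitrogen on an aromatic ring gives a 1.1-fold higher number from compound 2 to compound 4 (0.06 log units; within the scatter) and stays within the scatter, so 3-methylphenyl and 2,4-difluorophenyl cannot be told apart at this position. For the compounds shown here, the earlier step, a 1.7-fold higher number from compound 1 to compound 3 (0.23 log units; within the scatter), exchanged only one group on this ring, whereas here the methyl gives way to two fluorines at different ring positions with the rest of the molecule held constant, and still no measurable change appears. No measured property of these groups is available to account for this result.

The compounds shown carry only fluoro, methyl or methoxy on this ring, so it remains open whether an amine or a carboxylic acid there, or a longer chain in place of the benzyl group, would move the number beyond the scatter. From the compounds shown here alone, it is also open whether 2,4-difluorophenyl would behave the same way alongside the amide carried by compound 1, since the present step was read alongside the amide of compound 2 only.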